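Chloro on the benzoyl phenyl of compound 1

The source may hold more compounds than are shown below. What is called first, only, known or untested is meant among the compounds shown, and "the series" means these compounds.

Compound 1 `Cc1nnc(CN(C)C)n1-c1ccc(Cl)cc1C(=O)c1ccccc1` is the reference point in a functional assay on the whole organism (strain CF-1) with Mus musculus as the target; a lower number here means that less compound is needed, a higher number that more compound is needed for the effect; compound 1 gives 2.2 mg/kg, the highest of the three numbers recorded. Compound 2 `CCNCc1nnc(C)n1-c1ccc(Cl)cc1C(=O)c1ccccc1` gives 1 mg/kg in this assay, and compound 3 `CNCc1nnc(C)n1-c1ccc(Cl)cc1C(=O)c1ccccc1` gives 0.8 mg/kg. The step of a 2.2-fold lower number from compound 1 to compound 2 (0.34 log units; beyond the scatter) and the step of a 2.8-fold lower number from compound 1 to compound 3 (0.44 log units; beyond the scatter) both go beyond the scatter, while the step of a 1.3-fold lower number from compound 2 to compound 3 (0.10 log units; within the scatter) stays within it.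

Compound 4 `Cc1nnc(CN(C)C)n1-c1ccc(Cl)cc1C(=O)c1ccccc1Cl` differs from compound 1 by chloro in place of hydrogen on an aromatic carbon; the same difference, cut one bond further out, reads phenyl to 2-chlorophenyl. Within the data shown here, every measured step so far alters the amine side of the molecule, and none touches the phenyl ring, so no measured step bears on this change. With nothing in the data pointing in either direction, the expectation for compound 4 is a step of no change at the digits printed from compound 1 to compound 4 (within the scatter) that stays within the scatter. Compound 4 is therefore estimated at 2.2 mg/kg in this assay, with a range from 0.8 mg/kg to 6 mg/kg.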

Compound 4, dose for half-maximal effect: 0.25 mg/kg
Compound 4: middle estimate off by 8.8-fold (0.94 log units), on the high side, outside the stated range (below it).
By their numbers in this assay, from the lowest: compound 4; then compounds 3 and 2 (each within the scatter of the next); then compound 1.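

In this assay, chloro in place of hydrogen on an aromatic carbon, ortho to a large group, gives an 8.8-fold lower number from compound 1 to compound 4 (0.94 log units; beyond the scatter). Among these compounds, the phenyl ring, which no earlier step touched, is thus a place where a single added atom shifts the number, and this step is larger than either step on the amine side, a 2.2-fold lower number from compound 1 to compound 2 (0.34 log units; beyond the scatter) and a 2.8-fold lower number from compound 1 to compound 3 (0.44 log units; beyond the scatter). Nothing measured here says why the change has this effect.

The compounds shown leave open whether this shift is particular to chloro or whether fluoro, methyl or methoxy at the same place would give a similar number. They also leave open whether the 2-chlorophenyl group and the methylamino or ethylamino chains of compound 3 and compound 2 would add up when combined in one molecule.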